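Swapping the Benzyl Tail for a Dithiocarbamate Side Chain

The source may hold more compounds than are shown below. What is called first, only, known or untested is meant among the compounds shown, and "the series" means these compounds.

Compound 2 `O=c1cc(Cn2cc(CCc3ccccc3)nn2)c2ccc(O)cc2o1` was tested in a functional assay on CFPAC-1 cells (Homo sapiens) for inhibition, read by MTT assay, with a stated time of 72 h (a lower number here means a stronger inhibitor, a higher number a weaker inhibitor), where compound 2 gives > 100000 nM, which is a limit of the assay and not a number. Compound 1 `O=c1cc(Cn2cc(CCO)nn2)c2ccc(O)cc2o1` in this assay gives > 100000 nM, likewise only a limit. The step from compound 1 to compound 2, a step that the two limits leave unreadable from compound 1 to compound 2, cannot be given a size, since the limit of > 100000 nM in this assay, at which 2 of the 2 values shown sit, shows where both values sit. Compound 3 `O=c1cc(Cn2cc(CSC(=S)N3CCOCC3)nn2)c2ccc(O)cc2o1` differs from compound 2 by a group of 9 heavy atoms (5 carbon, 1 nitrogen, 1 oxygen, 2 sulfur; one six-membered non-aromatic ring with 2 hetero atoms) in place of a group of 7 heavy atoms (7 carbon; one six-membered aromatic ring of carbon only), on a saturated chain carbon bound to an aromatic carbon. The only measured step is this unreadable one, so nothing shown points to a change in either direction, and both known values rest at a limit. For compound 3 no move beyond the scatter is expected, and its step of a number no higher from compound 2 to compound 3 (the limit leaves the size open) is estimated to stay within the scatter. Compound 3 is therefore expected to give 100000 nM, within 30000 nM to 300000 nM, and most likely again as a limit only.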

Compound 3, half-maximal inhibitory concentration: 56300 nM
The estimate for compound 3 lay 1.8-fold (0.25 log units) above the measured number, within the range that was stated.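

In this assay, among these compounds, compound 3 gives 56300 nM, the only value that is a number, so a measurable reading is possible with a group at this saturated chain carbon. The change reads as an at least 1.7-fold lower number from compound 2 to compound 3 (0.24 log units; that floor lies within the scatter), and the comparison with the hydroxy-bearing side chain reads as an at least 1.7-fold lower number from compound 1 to compound 3 (0.24 log units; that floor lies within the scatter), so neither step yet shows a real gain. The true size of both steps stays open, since the other two values are limits and not numbers: the limit of > 100000 nM in this assay, at which 2 of the 3 values shown sit.

The compounds shown do not separate the part of the new group that holds the two sulfur atoms from its six-membered non-aromatic ring. As far as these compounds go, what a simple amine, a carboxylic acid or a longer chain would give at this place also remains open.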